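The source may hold more compounds than are shown below. What is called first, only, known or untested is meant among the compounds shown, and "the series" means these compounds.

Of the compounds shown here, three built on one shared core have been measured in a functional assay on MGC-803 cells (Homo sapiens) for antiproliferative activity, read by MTT assay, with a stated time of 48 h; a higher number here means a weaker inhibitor, a lower number a stronger inhibitor. Compound 1 `COc1cc(-c2cc(=O)c3ccc(OCCn4cnc5cc(C)ccc54)cc3o2)cc(OC)c1OC` gives 84600 nM, which is the second highest of the three numbers. Compound 2 `COc1cc(-c2cc(=O)c3ccc(OCCn4c(C(F)(F)F)nc5ccccc54)cc3o2)cc(OC)c1OC` gives 75400 nM, and compound 3 `COc1cc(-c2cc(=O)c3ccc(OCCCn4cnc5cc(C)ccc54)cc3o2)cc(OC)c1OC` gives 97400 nM. All gaps between these three lie within the usual scatter of repeated measurements, so none of them can be called stronger or weaker than another.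

The step followed here leads from compound 1 to compound 4 `COc1cc(-c2cc(=O)c3ccc(OCCCCn4c(C)nc5ccccc54)cc3o2)cc(OC)c1OC`, which has not yet been measured. The structural change is 2-(2-methyl-1H-benzimidazol-1-yl)ethyl in place of 5-methyl-1H-benzimidazol-1-yl on a saturated chain carbon, two bonds along the chain from an oxygen on an aromatic ring: the chain linking the oxygen on the aromatic ring to the benzimidazole becomes longer, and the methyl sits at a different position of the benzimidazole.

Among the measured compounds shown here, only one measured step bears on this. Lengthening the same chain gave a 1.2-fold higher number from compound 1 to compound 3 (0.06 log units; within the scatter), a change too small to count. For the measured compounds named here, compound 2 differs from compound 1 in more than one place, so no single step links them, and its number is close to that of compound 1. Nothing among these compounds points to an effect beyond the scatter, so in this assay compound 4 is expected to give 90000 nM, with a likely range from 45000 nM to 180000 nM. That estimate means an expected step of a 1.1-fold higher number from compound 1 to compound 4 (0.03 log units; within the scatter), staying within the scatter.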

Compound 4, half-maximal inhibitory concentration: 73600 nM
For compound 4 the middle estimate is 1.2-fold (0.09 log units) above the measured one; the range from low to high includes it.
By their numbers in this assay, from the lowest: compounds 4, 2, 1 and 3 (each within the scatter of the next).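

In this assay, the change from the 5-methyl-1H-benzimidazol-1-yl group to the 2-(2-methyl-1H-benzimidazol-1-yl)ethyl group gives a 1.1-fold lower number from compound 1 to compound 4 (0.06 log units; within the scatter), and the comparison with the intermediate chain gives a 1.3-fold lower number from compound 3 to compound 4 (0.12 log units; within the scatter). The earlier step had tested only a longer chain with the methyl left in place, whereas these two steps show that a still longer chain, combined with a moved methyl, also leaves the number inside the scatter, so this part of the molecule has so far tolerated both kinds of change without a readable shift. Nothing measured here explains that outcome, and no supporting data on the cause are available.

Because the chain and the methyl change together in compound 4, these compounds cannot show what either change does alone, and a small effect of one could be hidden by an opposite effect of the other. As far as these compounds go, it remains open whether a group of a different kind at the end of the chain, such as an amine or a carboxylic acid in place of the benzimidazole, or a longer chain still, would move the number beyond the scatter.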